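A Four-Membered Ring Replaces a Chain on the Core

The source may hold more compounds than are shown below. What is called first, only, known or untested is meant among the compounds shown, and "the series" means these compounds.

Compound 1 `COc1ccc2c(c1)NC(=O)CN2c1nc(NCCCO)nc2ccccc12`: 10.2 nM
Compound 2 `COc1ccc2c(c1)NC(=O)CN2c1nc(Nc2ccc(C#N)cc2)nc2ccccc12`: 8.31 nM

Of the compounds shown here, two have been tested so far in a functional assay on MDA-MB-231 cells (Homo sapiens) for inhibition, read by sulforhodamine B assay, with a stated time of 48 h; a lower number here means a stronger inhibitor of growth, a higher number a weaker inhibitor of growth. In this assay compound 1 gives 10.2 nM, and compound 2 gives 8.31 nM. Compound 1 stands at one end of this pair, yet the step of a 1.2-fold lower number from compound 1 to compound 2 (0.09 log units; within the scatter) lies within the scatter, so the two compounds cannot be told apart on these numbers.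

Compound 3 `COc1ccc2c(c1)NC(=O)CN2c1nc(N2CC(OC)C2)nc2ccccc12` is the next one to be tested. It differs from compound 1 in a single place: 3-methoxyazetidin-1-yl in place of (3-hydroxypropyl)amino on an aromatic carbon. Among the measured compounds shown here, the only measured step that bears on it is a 1.2-fold lower number from compound 1 to compound 2 (0.09 log units; within the scatter), which also changed the group on that part of the shared core and left the number essentially unchanged. That change was of another kind, swapping one open substituent for another, whereas compound 3 brings in a four-membered non-aromatic ring and gives up both hydrogen-bond donors. For the measured compounds named here, with one flat step as the sole guide, the expectation for compound 3 is a step of a 1.2-fold higher number from compound 1 to compound 3 (0.07 log units; within the scatter), that is, no movement beyond the scatter, with a wide range to allow for the new ring. Compound 3 is therefore estimated at 12 nM, within 4 nM to 40 nM.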

Compound 3, concentration for 50% growth inhibition: 53.1 nM
Compound 3: middle estimate off by 4.4-fold (0.65 log units), on the low side; the measured number lies above the stated range.
By their numbers in this assay, from the lowest: compounds 2 and 1 (each within the scatter of the next); then compound 3.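

In this assay, this position on the shared core does not tolerate every change: compounds 1 and 2, which carry very different groups attached through an amino nitrogen, lie within the scatter of each other, yet the 3-methoxyazetidin-1-yl group gives a 5.2-fold higher number from compound 1 to compound 3 (0.72 log units; beyond the scatter) and a 6.4-fold higher number from compound 2 to compound 3 (0.81 log units; beyond the scatter). Going from compound 1 to compound 3, the substituent loses its hydrogen-bond donors and gains a four-membered non-aromatic ring, while its number of hydrogen-bond acceptors stays the same, so this single step changes two features at once. No measurement presented here explains the weaker growth inhibition of compound 3.

The compounds shown leave open whether the step follows the new ring, the missing donors or both. A 3-hydroxyazetidin-1-yl group, which keeps the ring and carries a hydroxyl, and a (3-methoxypropyl)amino group, which keeps an open chain and its amino hydrogen but ends in a methoxy, would each separate part of that question.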